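Swapping the pyridine ring of compound 3 for a fluorinated phenyl

The source may hold more compounds than are shown below. What is called first, only, known or untested is meant among the compounds shown, and "the series" means these compounds.

Of the compounds shown here, three sharing one core have been measured in a functional assay for agonist activity at G protein-coupled receptor 88 (Homo sapiens), read by HTRF and cAMP accumulation; on this read-out higher numbers stand for an effect only at larger amounts of compound and lower numbers for an effect already at smaller amounts. Compound 1 `CC(C)C[C@H](N)CN(C(=O)C(C)Cc1ccccc1)c1ccc(-c2ccccc2)cc1` gives 1.2 nM, and compound 2 `O=C([C@@H]1C[C@H]1c1ccccc1)N(CC1CCCNC1)c1ccc(-c2ccccc2)cc1` gives 10 nM. Compound 3 `CC(C)C[C@H](N)CN(C(=O)[C@@H]1C[C@H]1c1ccccc1)c1ccc(-c2cccnc2)cc1` gives 10000 nM, the highest of the three numbers: it lies well beyond the usual scatter from compound 2 and further still from compound 1, so compound 3 is clearly the weakest of the three in this assay.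

Compound 4 `CC(C)C[C@H](N)CN(C(=O)[C@@H]1C[C@H]1c1ccccc1)c1ccc(-c2ccccc2F)cc1` has not been measured yet. It differs from compound 3 in one place: 2-fluorophenyl in place of pyridin-3-yl on an aromatic carbon. Compounds 1 and 2 both carry a ring of carbon only at this position and give low numbers, while compound 3, with a pyridine ring there, gives a high one. On that basis the step from compound 3 to compound 4 is expected to be large, toward lower numbers, estimated as a 500-fold lower number from compound 3 to compound 4 (2.70 log units; beyond the scatter). For compound 4 the expected value is 20 nM, with a likely range from 3 nM to 150 nM.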

Compound 4, half-maximal effective concentration: 1600 nM
Estimate against measurement, compound 4: 80-fold (1.90 log units) below; measured number above the stated range.
By their numbers in this assay, from the lowest: compound 1; then compound 2; then compound 4; then compound 3.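

In this assay, replacing pyridin-3-yl with 2-fluorophenyl gives a 6.3-fold lower number from compound 3 to compound 4 (0.80 log units; beyond the scatter), a modest change that still lies beyond the usual scatter. This position therefore responds to the change, but on this core a six-membered aromatic ring of carbon only does not by itself bring a very low number, since compound 4 gives 1600 nM. Nothing measured here explains why the step has this size.

Two things change at once, as the ring nitrogen leaves and a fluorine enters, so the compounds shown cannot separate the share of each in the step. Also open, on these data alone, is how an unsubstituted phenyl, or a methoxy group or nitrile in place of the fluorine, would read at this position on the same core.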